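Benzyl ether analogues at the ring oxygen: next step

The source may hold more compounds than are shown below. What is called first, only, known or untested is meant among the compounds shown, and "the series" means these compounds.

Measured so far in an ADME assay on HEK293 cells for agonist activity at Toll-like receptor 8 (Homo sapiens), read by a luciferase reporter, with a stated time of 6 h; on this read-out higher numbers stand for an effect only at larger amounts of compound and lower numbers for an effect already at smaller amounts:
compound 1 `CCCCNc1nc(N)nc2cccc(OC)c12` gives 0.1 uM
compound 2 `CCCCNc1nc(N)nc2cccc(OCCOC)c12` gives 0.2 uM
compound 3 `CCCCNc1nc(N)nc2cccc(OCc3ccccc3)c12` gives 1.66 uM

Compound 3 stands highest of the three numbers in this assay. The two steps that lead to it both enlarge the group on the saturated chain carbon bound to the oxygen on the aromatic ring: a 17-fold higher number from compound 1 to compound 3 (1.22 log units; beyond the scatter), and an 8.3-fold higher number from compound 2 to compound 3 (0.92 log units; beyond the scatter). The remaining step, a 2.0-fold higher number from compound 1 to compound 2 (0.30 log units; within the scatter), stays within the scatter.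

Compound 4 `CCCCNc1nc(N)nc2cccc(OCc3ccccc3OC)c12` differs from compound 3 by methoxy in place of hydrogen on an aromatic carbon. Going by the values given here, no measured step touches the phenyl itself, so nothing directly reports what a methoxy on that ring does. Among the compounds with values here, the steps that bear on it only indirectly are those that introduced the phenyl, one large and one modest, and the single within-scatter step in which a methoxymethyl entered. Taken together, they give no ground to expect the methoxy to move the number by more than the scatter in either direction, and compound 4 is therefore expected to stay close to compound 3, with the estimated step of a 1.0-fold higher number from compound 3 to compound 4 (0.01 log units; within the scatter).

The estimate for compound 4 in this assay is 1.7 uM, with a range from 0.6 uM to 5 uM.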

Compound 4, minimum effective concentration: > 25 uM
Compound 4 ended at the assay's limit (the forecaster's own chance of this, stated with the estimate: 5%); middle value at least 14-fold (1.16 log units) from the limit.
By their numbers in this assay, from the lowest: compounds 1 and 2 (each within the scatter of the next); then compound 3. At a limit, above all of these: compound 4.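

In this assay compound 4 gives > 25 uM, which is a limit of the assay and not a number: the limit of > 25 uM in this assay, at which 1 of the 4 values shown sits. Going by these compounds alone, the earlier steps showed only that the group on the saturated chain carbon bound to the oxygen on the aromatic ring can shift the number, whereas this one shows that the phenyl of that group is itself sensitive to substitution: methoxy in place of hydrogen on an aromatic carbon, ortho to a large group, gives an at least 15-fold higher number from compound 3 to compound 4 (1.17 log units; beyond the scatter). Against the two smaller ethers the gap is wider still, at an at least 120-fold higher number from compound 2 to compound 4 (2.09 log units; beyond the scatter) and an at least 250-fold higher number from compound 1 to compound 4 (2.39 log units; beyond the scatter), which puts the 2-methoxyphenyl group at the far end of this small series.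

Going by these compounds, how far the true number of compound 4 lies past the limit stays open, and so does whether the step belongs to methoxy as such or to any group ortho to a large group. A methyl, a chlorine or a hydroxyl in that place, or methoxy elsewhere on the same ring, would separate these readings.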